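The source may hold more compounds than are shown below. What is called first, only, known or untested is meant among the compounds shown, and "the series" means these compounds.

Of the compounds shown here, three of a shared core have been measured in an assay on PMNL cells for inhibition of Polyunsaturated fatty acid 5-lipoxygenase (Homo sapiens), read by HPLC, with stated times of 15 min and 10 min; a higher number here means a weaker inhibitor, a lower number a stronger inhibitor. Compound 1, `O=C1N=C(c2ccc(Cl)cc2)S/C1=C\c1cccc(Oc2ccccc2)c1`, gives 90 nM in this assay. Compound 2, `COc1ccc(/C=C2\SC(c3ccc(Cl)cc3)=NC2=O)c2ccccc12`, gives 130 nM. Compound 3, `CCC(=O)Nc1ccc(C2=NC(=O)/C(=C/c3ccc(OC)cc3)S2)cc1`, gives 760 nM, the highest of the three numbers and thus the weakest inhibitor of the set, since its gaps to compound 2 and to compound 1 both lie beyond the usual scatter.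

Compound 4, `CCCOc1ccc(C2=NC(=O)/C(=C/c3ccc(OC)cc3)S2)cc1`, has not yet been measured. It differs from compound 3 in one place: propoxy in place of propanoylamino on an aromatic carbon. An amide with a hydrogen-bond donor gives way to an ether that keeps the chain length but loses that donor.

For the measured compounds named here, no measured pair shows a comparable change, so there is no step on which to lean. The expectation is a modest step in this assay, a 2.5-fold lower number from compound 3 to compound 4 (0.40 log units; beyond the scatter), toward a stronger inhibitor, since the ether-bearing compound 2 gives 130 nM while the amide-bearing compound 3 gives 760 nM, though those two also differ elsewhere. Compound 4 is therefore estimated at 300 nM, with a range from 80 nM to 1200 nM.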

Compound 4, half-maximal inhibitory concentration: 210 nM
The estimate for compound 4 lay 1.4-fold (0.15 log units) above the measured number; low and high end bracket the measured number.
By their numbers in this assay, from the lowest: compounds 1, 2 and 4 (each within the scatter of the next, the first and the last beyond it); then compound 3.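

In this assay, for the compounds shown here, putting propoxy in place of propanoylamino on this aromatic carbon, para to a large group, gives a 3.6-fold lower number from compound 3 to compound 4 (0.56 log units; beyond the scatter), the first step here in which only this position changes. The swap removes the amide's nitrogen and its hydrogen-bond donor, yet inhibition gets stronger rather than weaker, so in this pair that donor is not needed for activity at this level. Nothing measured here explains the size or direction of the step.

The compounds shown leave open how a longer chain such as butoxy, a simple amine or a carboxylic acid would fare at this position. They also leave open whether the same swap would give a similar step with a different group elsewhere on the shared core.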